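The source may hold more compounds than are shown below. What is called first, only, known or untested is meant among the compounds shown, and "the series" means these compounds.

Measured so far:
compound 1 `N=C(N)c1ccc(-c2ccc(-c3cc(Cl)cc(Cl)c3)s2)cc1`: 2480 nM
compound 2 `N=C(N)c1ccc(-c2ccc(-c3ccc(Cl)cc3)s2)cc1F`: 1620 nM
compound 3 `COc1cc(OC)cc(-c2ccc(-c3ccc(C(=N)N)c(F)c3)s2)c1`: 1850 nM

In a functional assay on UACC-257 cells (Homo sapiens) for inhibition, read by sulforhodamine B assay, with a stated time of 48 h (on this read-out higher numbers stand for weaker inhibition of growth and lower numbers for stronger inhibition of growth), compound 2 gives the lowest of the three numbers, but its gaps to compound 3 and to compound 1 both sit within the scatter, so no ordering among the three is claimed. Compound 4 `COc1ccc(-c2ccc(-c3ccc(C(=N)N)c(F)c3)s2)cc1` has not yet been measured. It differs from compound 2 in one place: methoxy in place of chloro on an aromatic carbon. Three compounds carrying different substituents on that ring give numbers that do not separate, so no step beyond the scatter is expected in this assay from this change; the number for compound 4 is expected near that of compound 3, which gives 1850 nM. For compound 4 the estimate is 2000 nM, with a range of 900 nM to 4500 nM. The expected step is a 1.2-fold higher number from compound 2 to compound 4 (0.09 log units; within the scatter), within the scatter.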

Compound 4, concentration for 50% growth inhibition: 1840 nM
Compound 4: middle estimate off by 1.1-fold (0.04 log units), on the high side, within the range that was stated.
By their numbers in this assay, from the lowest: compounds 2, 4, 3 and 1 (each within the scatter of the next).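

Within the data shown here, compound 2 and compound 4 form the first pair that differs in one place, and in this assay the change gives a 1.1-fold higher number from compound 2 to compound 4 (0.06 log units; within the scatter). On an aromatic carbon para to a large group, methoxy in place of chloro therefore leaves the number within the scatter, so this position tolerates both groups in this assay. No other data bear on this result.

Open, from the compounds shown here alone, is whether an amine or a carboxylic acid on this carbon would give a step beyond the scatter. Going by these compounds, whether the same change reads alike without the fluoro group also remains open.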